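The source may report more compounds than this note shows. Statements on the series, on what has been measured and on what is new or still open speak of the compounds shown alone.

Measured compounds in a physicochemical assay for solubility, using the shake flask method, measured as kinetic solubility, with a stated time of 20 h, at pH 2; on this read-out higher numbers stand for higher solubility and lower numbers for lower solubility:
- compound 1, `COc1cccc(Nc2cc3[nH]c(-c4cccc(C(F)(F)F)c4)nc3cn2)n1`, compound 1 gives 85000 nM
- compound 2, `COc1ccc(Nc2cc3[nH]c(-c4cccc(C(F)(F)F)c4)nc3cn2)nc1`, compound 2 gives only a limit of this assay, < 5000 nM
- compound 3, `FC(F)(F)c1cccc(-c2nc3cnc(Nc4cnccn4)cc3[nH]2)c1`, compound 3 gives 155000 nM

Compound 1 stands lowest of the two real numbers, with compound 3 nearest; the two differ only within the scatter, so no order between them is claimed. The value of compound 2 is a limit (the limit of < 5000 nM in this assay, at which 1 of the 3 values shown sits) and carries no number.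

The unmeasured compound 4, `FC(F)(F)c1cccc(-c2nc3cnc(Nc4cccnn4)cc3[nH]2)c1`, differs from compound 1 in one place: pyridazin-3-yl in place of 6-methoxypyridin-2-yl on a nitrogen on an aromatic ring.

Among the measured compounds shown here, two measured steps bear on this change, both starting from the same 6-methoxypyridin-2-yl group on the same nitrogen. Moving to pyrazin-2-yl gave a 1.8-fold higher number from compound 1 to compound 3 (0.26 log units; within the scatter). Moving instead to 5-methoxypyridin-2-yl gave an at least 17-fold lower number from compound 1 to compound 2 (1.23 log units; beyond the scatter). Pyridazin-3-yl, like pyrazin-2-yl, is a six-membered aromatic ring with two hetero atoms and no methoxy group, so the step from compound 1 to compound 3 is taken as the closer guide, and no step beyond the scatter is expected in this assay.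

Compound 4 is therefore estimated at 120000 nM, with a range of 45000 nM to 320000 nM, which means an expected step of a 1.4-fold higher number from compound 1 to compound 4 (0.15 log units; within the scatter).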

Compound 4, solubility: 161000 nM
Beside the measured number, compound 4's estimate is 1.3-fold (0.13 log units) below it; the range from low to high includes it.
By their numbers in this assay, from the lowest: compounds 1, 3 and 4 (each within the scatter of the next). At a limit, below all of these: compound 2.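

In this assay, the pyridazin-3-yl group on this nitrogen gives a 1.0-fold higher number from compound 3 to compound 4 (0.02 log units; within the scatter), so a second ring with two hetero atoms and no methoxy group gives a result that cannot be told apart from the pyrazin-2-yl result. Taking out the 6-methoxypyridin-2-yl group for pyridazin-3-yl gives a 1.9-fold higher number from compound 1 to compound 4 (0.28 log units; within the scatter), again no step beyond the scatter, while the change from the 5-methoxypyridin-2-yl group gives an at least 32-fold higher number from compound 2 to compound 4 (1.50 log units; beyond the scatter), which leaves that group as the only one shown that stands apart from the others at this position. The value of compound 2 remains a limit: the limit of < 5000 nM in this assay, at which 1 of the 4 values shown sits.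

Open is whether the gap seen with the 5-methoxypyridin-2-yl group belongs to the methoxy group, to the ring nitrogen or to the two together, since a single compound carries that arrangement and no unsubstituted pyridin-2-yl group is among those shown. Also open, as far as these compounds go, is how this assay responds to a ring on this nitrogen that carries an amine or a carboxylic acid, or to an open chain in place of the ring.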